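A few compounds are considered here, and "the series" means these few. Any claim that something is new, unique, unknown or untested is made for them only; others in the source may bear on it.

Three compounds sharing one core have been examined in an ADME assay on microsomes from liver (Rattus norvegicus), read by LC-MS, with a stated time of 90 min; a lower number here means that the liver removes a smaller share, a higher number that the liver removes a larger share of the compound in one pass. Compound 1 `CC(C)(C)n1c(=O)[nH]c2ncc(Br)nc21` carries a tert-butyl group and a bromine substituent, and in this assay compound 1 gives 0.3. Compound 2 `O=c1[nH]c2ncc(Br)nc2n1C1CCCCC1` carries a cyclohexyl group and a bromine substituent; for this assay compound 2 shows "not determined" (no result reported). Compound 3 `CCC(CC)n1c(=O)[nH]c2nccnc21` carries a pentan-3-yl group and no bromine; in this assay compound 3 shows "not determined" (no result reported), so no number stands for it, and compound 2 is the one further entry that also lacks a number. Compound 4 `CCC(CC)n1c(=O)[nH]c2ncc(OC)nc21` is reached from compound 3 by a single change: methoxy in place of hydrogen on an aromatic carbon. Going by the values given here, no measured pair in this set differs in only one place, so no step of known size is available to guide the outcome, and the value of compound 1 is the only anchor for the scale. The direction of the step is therefore open, and a move of any size, or none beyond the scatter, remains possible. For compound 4 the hepatic extraction ratio is expected near 0.4, with a range from 0.2 to 0.65.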

Compound 4, hepatic extraction ratio: > 0.7
Compound 4: a limit, no number; the forecaster's own chance of this, stated with the estimate: 10%; at least 0.30 between middle value and limit.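

In this assay compound 4 gives > 0.7, which is a limit and not a number. Going by these compounds alone, compound 3 has no single number, so no step from compound 3 to compound 4 can be read. The compounds shown leave open how far, and in which direction, methoxy in place of hydrogen moves the share the liver removes.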